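Swapping Phenyl for Cyclohexyl on the Weak Stereoisomer

A few compounds are considered here, and "the series" means these few. Any claim that something is new, unique, unknown or untested is made for them only; others in the source may bear on it.

In a functional assay for inhibition, with Rattus norvegicus as the target (on this read-out lower numbers stand for stronger inhibition and higher numbers for weaker inhibition), compound 3 `C[C@H](/N=c1\c(O)c(O)\c1=N/c1ccc(C#N)cc1)c1ccccc1` sits at the weak end of this small set. Compound 3 gives > 30000 nM, which is a limit of the assay and not a number. Compound 2 `C[C@@H](/N=c1\c(O)c(O)\c1=N/c1ccc(C#N)cc1)c1ccccc1` reaches 56 nM, and the gap is an at least 530-fold higher number from compound 2 to compound 3 (2.72 log units; beyond the scatter). That gap stands out because of the fact that compounds 2 and 3 differ only in the configuration as drawn. Compound 1 `CCC(CC)/N=c1\c(O)c(O)\c1=N/c1ccc(C#N)cc1`, carrying pentan-3-yl instead of 1-phenylethyl, gives 3340 nM. Its two steps are a 60-fold lower number from compound 1 to compound 2 (1.78 log units; beyond the scatter) and an at least 8.9-fold higher number from compound 1 to compound 3 (0.95 log units; beyond the scatter), so in these compounds 1-phenylethyl can either improve or worsen the number, depending on its configuration.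

Compound 4 `C[C@H](/N=c1\c(O)c(O)\c1=N/c1ccc(C#N)cc1)C1CCCCC1` has cyclohexyl in place of phenyl on a saturated chain carbon bound to a double-bonded nitrogen and a saturated chain carbon. Its stereocentre is drawn as in compound 3. Among the compounds with values here, no measured step makes this exact swap, so the evidence is indirect. Compound 4 shares its drawn configuration with compound 3, which points to weak inhibition, while compound 1 at 3340 nM shows that a compound without the phenyl can still give a measurable number. A modest move towards a lower number is therefore expected, and the estimated change is an at least 2.5-fold lower number from compound 3 to compound 4 (0.39 log units; beyond the scatter). For compound 4 the estimated value is 12000 nM, with an expected range from 3000 nM to 50000 nM.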

Compound 4, half-maximal inhibitory concentration: > 30000 nM
Compound 4 was reported as a limit (the forecaster's own chance of this, stated with the estimate: 40%); at least 2.5-fold (0.39 log units) between middle value and limit.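

In this assay, the swap of phenyl for cyclohexyl on this stereoisomer cannot be read, because compound 3 and compound 4 each give a limit of the assay and not a number: the limit of > 30000 nM in this assay, at which 2 of the 4 values shown sit. The other steps can be read and are large or at least modest, with an at least 530-fold higher number from compound 2 to compound 4 (2.72 log units; beyond the scatter) and an at least 8.9-fold higher number from compound 1 to compound 4 (0.95 log units; beyond the scatter). So a non-aromatic ring of carbon at this place, with the stereocentre drawn as in compound 3, gives no measurable number either, whereas the open-chain pentan-3-yl group of compound 1 does.

The compounds shown leave open how 1-cyclohexylethyl behaves with its stereocentre drawn as in compound 2, so it cannot be told whether the low number of compound 2 depends on phenyl or only on the configuration. Also open, on these data alone, is whether a longer chain, such as 1-phenylpropyl in place of 1-phenylethyl, would keep the gap between the two configurations.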